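The source may report more compounds than this note shows. Statements on the series, on what has been measured and on what is new or still open speak of the compounds shown alone.

Of the compounds shown here, three sharing one core have been measured in a functional assay on HT-29 cells (Homo sapiens) for inhibition, read by sulforhodamine B assay, with a stated time of 48 h; a lower number here means a stronger inhibitor of growth, a higher number a weaker inhibitor of growth. Compound 1 `O=C1C=COC(/C=C/c2ccccc2)C1` gives 124 uM. Compound 2 `O=C1C=COC(/C=C/c2ccc(C(F)(F)F)cc2)C1` gives 33.3 uM. Compound 3 `COc1ccc(/C=C/C2CC(=O)C=CO2)cc1` gives 204 uM, the highest number of the three, although the gap to its nearest neighbour, a 1.6-fold higher number from compound 1 to compound 3 (0.22 log units; within the scatter), lies within the scatter, so compound 1 and compound 3 cannot be told apart. Against compound 2 the gap is wider, a 6.1-fold higher number from compound 2 to compound 3 (0.79 log units; beyond the scatter), a modest step beyond the scatter. Among the measured compounds shown here, the only other resolved step among the measured compounds is a 3.7-fold lower number from compound 1 to compound 2 (0.57 log units; beyond the scatter).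

Compound 4 `COc1ccc(/C=C/C2CC(=O)C=CO2)cc1OC` differs from compound 3 in one place: methoxy in place of hydrogen on an aromatic carbon.

For the measured compounds named here, the one measured step of the same kind, a methoxy entering in place of hydrogen on an aromatic carbon, is a 1.6-fold higher number from compound 1 to compound 3 (0.22 log units; within the scatter), which stayed within the scatter. Going by the values given here, there is no measured example of a second methoxy entering ortho to a methoxy group, so that case is untested here. Among the compounds with values here, on the single comparable step, the change from compound 3 to compound 4 is expected to be a 1.1-fold higher number from compound 3 to compound 4 (0.05 log units; within the scatter), not beyond the scatter in this assay. Compound 4 is therefore estimated at 230 uM, with a range from 90 uM to 600 uM.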

Compound 4, concentration for growth inhibition (reported as GI): 123 uM
For compound 4 the middle estimate is 1.9-fold (0.27 log units) above the measured one, within the range that was stated.
By their numbers in this assay, from the lowest: compound 2; then compounds 4, 1 and 3 (each within the scatter of the next).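

In this assay, among the compounds shown here, the step is a 1.7-fold lower number from compound 3 to compound 4 (0.22 log units; within the scatter), so a second methoxy placed ortho to a methoxy group, a case the earlier compounds did not cover, does not shift the number beyond the scatter. The first methoxy step, a 1.6-fold higher number from compound 1 to compound 3 (0.22 log units; within the scatter), also stayed within the scatter, so neither methoxy step among these compounds can be told apart from repeat-measurement noise, whereas the step to trifluoromethyl, a 3.7-fold lower number from compound 1 to compound 2 (0.57 log units; beyond the scatter), is resolved. Nothing available here offers a measured explanation for this result.

The compounds shown leave open whether a different group at this same place, ortho to a methoxy group, such as an amine, a carboxylic acid or a longer chain, would give a step beyond the scatter. For the compounds shown here, they also leave open whether a trifluoromethyl group, the one change here that gave a resolved step, would have a comparable effect at this place, or whether the step seen from compound 1 to compound 2 belongs only to the place it occupies there.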